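The source may report more compounds than this note shows. Statements on the series, on what has been measured and on what is new or still open speak of the compounds shown alone.

Compound 1 `Oc1ccc(-c2cc(-c3ccccc3F)cc(-c3cccc(O)c3)n2)cc1` gives 6370 nM in a functional assay on T47D cells (Homo sapiens) for inhibition; on this read-out lower numbers stand for stronger inhibition and higher numbers for weaker inhibition. Compound 2 `Oc1ccc(-c2cc(-c3ccccc3F)cc(-c3ccc(O)cc3)n2)cc1`, which carries 4-hydroxyphenyl in place of 3-hydroxyphenyl on an aromatic carbon, gives 15100 nM in this assay, a change of a 2.4-fold higher number from compound 1 to compound 2 (0.37 log units; beyond the scatter). Compound 3 `Oc1cccc(-c2cc(-c3ccccc3OC(F)(F)F)cc(-c3cccc(O)c3)n2)c1` rests on a core whose difference from the core of compound 1 is not broken down here, and in this assay compound 3 gives 7950 nM. Compound 4 `Oc1ccc(-c2cc(-c3ccccc3OC(F)(F)F)cc(-c3cccc(O)c3)n2)cc1` is the not yet measured partner of compound 3, carrying (4-hydroxyphenyl in place of 3-hydroxyphenyl on an aromatic carbon). Among the measured compounds shown here, this is the same kind of change as the one from compound 1 to compound 2, though the place is meta to a 3-hydroxyphenyl group and meta to a large group rather than meta to a 2-fluorophenyl group and meta to a 4-hydroxyphenyl group. Since the change from compound 1 to compound 2 gave a 2.4-fold higher number from compound 1 to compound 2 (0.37 log units; beyond the scatter), compound 4 is expected to show a step of a 2.1-fold higher number from compound 3 to compound 4 (0.33 log units; beyond the scatter) from compound 3 in this assay. Compound 4 is therefore estimated at 17000 nM, with a likely range from 7000 nM to 40000 nM.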

Compound 4, half-maximal inhibitory concentration: 7300 nM
The estimate for compound 4 lay 2.3-fold (0.37 log units) above the measured number, within the range that was stated.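

The change from 3-hydroxyphenyl to 4-hydroxyphenyl gives in this assay a 1.1-fold lower number from compound 3 to compound 4 (0.04 log units; within the scatter), and set beside the earlier step on the core of compound 1, it does not differ from that step by more than the scatter allows: the same change on two cores in this assay, a 2.4-fold higher number (0.37 log units; beyond the scatter) from compound 1 to compound 2 and a 1.1-fold lower number (0.04 log units; within the scatter) from compound 3 to compound 4, 2.6-fold (0.41 log units) apart, within the scatter of two such steps. This shows that the two cores are compatible with one shared step, but it does not show that the step carries over, since a single pair on each core cannot fix its size. Trifluoromethoxy in place of fluoro gives a 1.1-fold higher number from compound 1 to compound 4 (0.06 log units; within the scatter).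

The compounds shown leave open how the change behaves with a chlorine or a methyl group in place of fluoro or trifluoromethoxy. They also leave open what an amine or a carboxylic acid would do in place of either hydroxyl.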